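Hydrazoline-series notes: para substituent swap on compound 2

This account rests on a few compounds, and the source may have more. Where it says the series, first, only, none or still open, it means among the compounds named here.

Measured so far:
- compound 1 `CC(C)(C)C1=NN(c2ccc(C(F)(F)F)cc2)C(c2ccc(O)cc2)C1`: 8800 nM
- compound 2 `Oc1ccc(C2CC(c3cccs3)=NN2c2ccc(Br)cc2)cc1`: 500 nM

In an assay on isolated protein for inhibition of protein kinase C zeta type (Homo sapiens), with a stated time of 4 min (a higher number here means a weaker inhibitor, a lower number a stronger inhibitor), compound 2 gives 500 nM, the lowest of the two numbers recorded so far. In this assay compound 1 gives 8800 nM, a markedly higher number, a gap well beyond the scatter. Compound 1 and compound 2 differ in two places at once, so no single-change step can be read from that pair; the two values only show that the combination of groups in compound 2 sits far ahead of the combination in compound 1.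

The next compound, compound 3 `Oc1ccc(C2CC(c3cccs3)=NN2c2ccc(C(F)(F)F)cc2)cc1`, keeps the core and the thiophene of compound 2 and changes one place: trifluoromethyl in place of bromo on an aromatic carbon. Without a measured step for this exchange, the expectation rests on compound 2 alone. The change is expected to shift this assay only modestly, with a slightly higher number more likely than a lower one, and a result within the scatter of compound 2 would not be surprising: the expected step from compound 2 to compound 3 is a 1.8-fold higher number from compound 2 to compound 3 (0.26 log units; within the scatter). Compound 3 is therefore expected to give about 900 nM in this assay, within a range from 300 nM to 3000 nM.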

Compound 3, half-maximal inhibitory concentration: 400 nM
The estimate for compound 3 lay 2.3-fold (0.35 log units) above the measured number; measured number inside the range.
By their numbers in this assay, from the lowest: compounds 3 and 2 (each within the scatter of the next); then compound 1.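

In this assay the exchange of bromo for trifluoromethyl, para to a large group, gives a step within the scatter (a 1.3-fold lower number from compound 2 to compound 3 (0.10 log units; within the scatter)), so this place does not separate the two groups, although the entering group has 4 heavy atoms and the leaving group 1. Compound 3 also supplies the single-change comparison that compounds 1 and 2 could not give: with thiophen-2-yl in place of tert-butyl on a carbon with a double bond to nitrogen, the step is large and beyond the scatter (a 22-fold lower number from compound 1 to compound 3 (1.34 log units; beyond the scatter)), so within this pair the gap follows that one exchange. Nothing available here bears on the reason for either step.

From the compounds shown here alone, how an amine or a carboxylic acid on the aromatic carbon would read in this assay remains open, since the two groups compared there give no trend. Also open, going by these compounds, is whether the large step belongs to thiophen-2-yl itself or would also appear with a phenyl ring or a longer chain on the carbon with a double bond to nitrogen.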